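The source may hold more compounds than are shown below. What is called first, only, known or untested is meant among the compounds shown, and "the series" means these compounds.

Values in a functional assay on MDA-MB-231 cells (Homo sapiens) for antiproliferative activity, read by MTT assay, with a stated time of 24 h; a lower number here means a stronger inhibitor, a higher number a weaker inhibitor:
- compound 1 `O=S(=O)(c1ccccc1)N1CCN(c2nccc(Oc3cc(Cl)cc(Cl)c3)n2)CC1`: > 50000 nM
- compound 2 `COc1ccccc1S(=O)(=O)N1CCN(c2nccc(Oc3cc(Cl)cc(Cl)c3)n2)CC1`: 16800 nM

Compound 1 gives only a limit, > 50000 nM, and not a number. Compound 3 `O=S(=O)(c1cccnc1)N1CCN(c2nccc(Oc3cc(Cl)cc(Cl)c3)n2)CC1` carries pyridin-3-yl in place of phenyl on a sulfonyl sulfur, pyridin-3-yl in place of phenyl on a sulfonyl sulfur. Among the measured compounds shown here, one measured step bears on this only loosely: an at least 2.9-fold lower number from compound 1 to compound 2 (0.47 log units; beyond the scatter), with methoxy in place of hydrogen on an aromatic carbon. For the measured compounds named here, that change differs from the one in compound 3, so only a small move towards a lower number in this assay is expected, possibly none beyond the scatter. The expected step is an at least 1.2-fold lower number from compound 1 to compound 3 (0.09 log units; that floor lies within the scatter). For compound 3 the estimated value is 40000 nM, with an expected range of 15000 nM to 90000 nM.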

Compound 3, half-maximal inhibitory concentration: 24800 nM
For compound 3 the middle estimate is 1.6-fold (0.21 log units) above the measured one, within the range that was stated.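

Pyridin-3-yl in place of phenyl on a sulfonyl sulfur gives a measured number in this assay, with an at least 2.0-fold lower number from compound 1 to compound 3 (0.30 log units; that floor lies within the scatter). The value for compound 1 is a limit and not a number, so the true size of this step stays unfixed: the limit of > 50000 nM in this assay, at which 1 of the 3 values shown sits. Pyridin-3-yl and 2-methoxyphenyl at this position cannot be told apart, with a 1.5-fold higher number from compound 2 to compound 3 (0.17 log units; within the scatter).

Open, as far as these compounds go, is how pyridin-4-yl compares with pyridin-3-yl at this position. Also open, from the compounds shown here alone, is what an amine or a carboxylic acid on the phenyl ring of compound 1 would give.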